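Hydroxyethyl in place of the hydroxypyridine

The compounds below may be only part of what the source reports. "The series", "measured", "known", "first", "only" and "open" are said of these compounds alone.

Going by the values given here, in an ADME assay on A549 cells (Homo sapiens) for cytotoxicity, read by resazurin assay, with a stated time of 48 h (a higher number here means that more compound is tolerated, a lower number that less compound is tolerated), compound 1 `O=C(Nc1ccc(NCc2ccc(F)cc2)cc1Cl)c1cc(Cl)ccc1O` gives 54400 nM and compound 2 `O=C(Nc1ccc(NCc2ccc(O)nc2)cc1Cl)c1cc(Cl)ccc1O` gives 98500 nM, so compound 2 stands within the scatter of its only measured neighbour. Compound 3 `O=C(Nc1ccc(NCCCO)cc1Cl)c1cc(Cl)ccc1O` has 2-hydroxyethyl in place of 6-hydroxypyridin-3-yl (2-hydroxyethyl in place of 6-hydroxypyridin-3-yl on a saturated chain carbon bound to a nitrogen on an aromatic ring), leaving no ring at this place. Among the compounds with values here, the only measured step here, a 1.8-fold higher number from compound 1 to compound 2 (0.26 log units; within the scatter), exchanged one ring for another, and no ring-free example has been measured. On that thin basis, no step beyond the scatter is expected in this assay. The expected step is a 1.3-fold lower number from compound 2 to compound 3 (0.12 log units; within the scatter). For compound 3 the estimated value is 75000 nM, with an expected range of 32000 nM to 170000 nM.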

Compound 3, half-maximal cytotoxic concentration: 106000 nM
Beside the measured number, compound 3's estimate is 1.4-fold (0.15 log units) below it; measured number inside the range.
By their numbers in this assay, from the lowest: compounds 1, 2 and 3 (each within the scatter of the next).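

In this assay, the step of a 1.1-fold higher number from compound 2 to compound 3 (0.03 log units; within the scatter) shows that 2-hydroxyethyl, with no ring, can stand at this place on a saturated chain carbon bound to a nitrogen on an aromatic ring without leaving the scatter. The step of a 1.9-fold higher number from compound 1 to compound 3 (0.29 log units; within the scatter) gives the same reading against 4-fluorophenyl, so all three groups at this place remain within the scatter. No measurement here bears on why these numbers stay together.

On these data alone, whether an amine, a carboxylic acid or a longer chain at this place would give a step beyond the scatter stays open.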